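Two Amines in Place of a Cyanosulfanyl Chain End

The compounds below may be only part of what the source reports. "The series", "measured", "known", "first", "only" and "open" are said of these compounds alone.

Three measured compounds share one core and differ only in the side chain. In an assay on isolated protein for inhibition of Myeloperoxidase (Homo sapiens), read by ELISA, with a stated time of 5 min (a lower number here means a stronger inhibitor, a higher number a weaker inhibitor), compound 1 `NCCSCCc1c[nH]c2ccc(F)cc12` gives 8 nM. Compound 2 `CCSCCc1c[nH]c2ccc(F)cc12` reaches only a limit of the assay, > 100 nM, in this assay. Compound 3 `N#CSCCCc1c[nH]c2ccc(F)cc12` gives 23 nM in this assay, the highest of the two numbers shown, separated from its nearest neighbour by a 2.9-fold higher number from compound 1 to compound 3 (0.46 log units; beyond the scatter). Compound 4 `NCC(N)CCc1c[nH]c2ccc(F)cc12` has not been measured; it differs from compound 3 by 1,2-diaminoethyl in place of (cyanosulfanyl)methyl on a saturated chain carbon, two bonds along the chain from an aromatic carbon. Among the compounds with values here, two measured steps bear on this change. Removing the amino group gave an at least 12-fold higher number from compound 1 to compound 2 (1.09 log units; beyond the scatter), and compound 2 sits at the limit of > 100 nM in this assay, at which 1 of the 3 values shown sits, so that step may be larger still. Adding the nitrile in place of the ethyl gave an at least 4.3-fold lower number from compound 2 to compound 3 (0.63 log units; beyond the scatter). Compound 4 returns an amino group, as part of the 1,2-diaminoethyl chain, and the expected step of a 2.9-fold lower number from compound 3 to compound 4 (0.46 log units; beyond the scatter) is a modest move to a lower number, roughly back to where compound 1 stands at 8 nM. Compound 4 is therefore estimated at 8 nM, between 3 nM and 25 nM.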

Compound 4, half-maximal inhibitory concentration: 26 nM
Estimate against measurement, compound 4: 3.3-fold (0.51 log units) below; measured number above the stated range.
By their numbers in this assay, from the lowest: compound 1; then compounds 3 and 4 (each within the scatter of the next). At a limit, above all of these: compound 2.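

In this assay, at this place, a saturated chain carbon two bonds along the chain from an aromatic carbon, 1,2-diaminoethyl and (cyanosulfanyl)methyl cannot be told apart, with a 1.1-fold higher number from compound 3 to compound 4 (0.05 log units; within the scatter). Within the data shown here, two amino groups on the chain also do not match the single amino group of the sulfur-containing chain in compound 1, with a 3.3-fold higher number from compound 1 to compound 4 (0.51 log units; beyond the scatter), while the ethylsulfanyl chain compares as an at least 3.8-fold lower number from compound 2 to compound 4 (0.58 log units; beyond the scatter). Compound 2 is a limit of the assay and not a number, so that last step is only a bound: the limit of > 100 nM in this assay, at which 1 of the 4 values shown sits.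

Which of the two amino groups in compound 4 matters, or whether both do, stays open. A chain carrying a single amine, such as aminomethyl, or a longer chain ending in an amine would help to separate them.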